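From Fluoro to Bromo in a Growth Inhibition Series

The source may hold more compounds than are shown below. What is called first, only, known or untested is meant among the compounds shown, and "the series" means these compounds.

In a functional assay on MCF7 cells (Homo sapiens) for inhibition, read by MTT assay, with a stated time of 48 h (on this read-out lower numbers stand for stronger inhibition of growth and higher numbers for weaker inhibition of growth), compound 1 (`COc1ccc(C(=O)N2N=C(c3ccccc3)CC2c2cn(C)c3ccccc23)cn1`) gives 4310 nM and compound 2 (`COc1ccc(C2=NN(C(=O)c3cccnc3)C(c3cn(C)c4ccc(Br)cc34)C2)cc1OC`) gives 1170 nM while compound 3 (`COc1ccc2c(c1)c(C1CC(c3ccc(F)cc3)=NN1C(=O)c1ccc(OC)nc1)cn2C`) gives 480 nM as the lowest of the three numbers, with both gaps beyond the scatter. Compound 4 (`COc1ccc2c(c1)c(C1CC(c3ccc(Br)cc3)=NN1C(=O)c1ccc(OC)nc1)cn2C`) differs from compound 3 by bromo in place of fluoro on an aromatic carbon, para to a large group (bromo in place of fluoro on an aromatic carbon). Among the compounds with values here, no measured pair here isolates such a change, so no step beyond the scatter is expected in this assay and no firm direction can be given. The estimate amounts to a 1.1-fold lower number from compound 3 to compound 4 (0.03 log units; within the scatter) as the expected step. For compound 4 the expected value is 450 nM (estimated range 180 nM to 1100 nM).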

Compound 4, concentration for 50% growth inhibition: 6960 nM
Compound 4: middle estimate off by 15-fold (1.19 log units), on the low side; the measured number lies above the stated range.
By their numbers in this assay, from the lowest: compound 3; then compound 2; then compounds 1 and 4 (each within the scatter of the next).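

In this assay, within the data shown here, bromo in place of fluoro on an aromatic carbon, para to a large group, gives a 15-fold higher number from compound 3 to compound 4 (1.16 log units; beyond the scatter), the first comparison here that isolates a single place. Among these compounds, the 4-fluorophenyl position is therefore sensitive to which halogen it carries, something the earlier compounds, which differ in more than one place, could not show. No measurement shown here bears on the reason for this step. As far as these compounds go, whether chloro, methyl or plain hydrogen at this place would stay close to compound 3 or fall toward compound 4 remains open.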